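Thiosemicarbazones of heteroaryl aldehydes: antiproliferative series notes

The source may hold more compounds than are shown below. What is called first, only, known or untested is meant among the compounds shown, and "the series" means these compounds.

Measured so far:
compound 1 `NC(=S)N/N=C/c1cc2cccnc2s1` — 100000 nM
compound 2 `NC(=S)N/N=C/c1ccc2ccccc2n1` — 32700 nM
compound 3 `CN(C)C(=S)N/N=C/c1nc2ccccc2s1` — 830 nM

All three were run in a functional assay on SGC-7901 cells (Homo sapiens) for antiproliferative activity, read by sulforhodamine B assay, with a stated time of 72 h; a higher number here means a weaker inhibitor, a lower number a stronger inhibitor. Compound 2 holds the second highest number of the three; its nearest neighbour is compound 1, which gives 100000 nM, a higher number beyond the scatter, while compound 3 is furthest away with 830 nM, far lower. Going by the values given here, compound 3 carries two methyl groups on the thioamide nitrogen and sits on a different core, so no single-change step can be drawn between any pair of the measured compounds.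

The next compound is compound 4 `COc1ccc(NC(=S)N/N=C/c2ccc3ccccc3n2)cc1`. Relative to compound 2 the change is 4-methoxyphenyl in place of hydrogen on an amide-type nitrogen; the core of compound 2 is kept.

Among the compounds with values here, no measured step with only this change exists. Within the data shown here, the expectation rests on the observation that the one compound with a substituted thioamide nitrogen, compound 3, gives the lowest number, although its core also differs, so the size is uncertain. A downward step beyond the scatter is expected, and this estimate means a 6.5-fold lower number from compound 2 to compound 4 (0.82 log units; beyond the scatter). For compound 4 in this assay the expected value is 5000 nM, with a range from 1000 nM to 25000 nM.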

Compound 4, half-maximal inhibitory concentration: 89600 nM
Compound 4: the middle estimate sits 18-fold (1.25 log units) below what was measured, outside the stated range (above it).
By their numbers in this assay, from the lowest: compound 3; then compound 2; then compounds 4 and 1 (each within the scatter of the next).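

In this assay the series gains its first single-change step, and it runs upward: 4-methoxyphenyl in place of hydrogen on the amide-type nitrogen gives a 2.7-fold higher number from compound 2 to compound 4 (0.44 log units; beyond the scatter) and leaves the core of compound 2 unchanged. This position on that core therefore tolerates a large aryl group with only a modest loss of antiproliferative activity, but the group brings no gain, and substitution on this nitrogen cannot be taken as favourable in itself. No measured data on these compounds explain the direction of this step.

On these data alone, it remains open whether the outcome belongs to the aryl group as a whole or to its methoxy substituent, which a plain phenyl group on the same nitrogen would separate, and whether a small group such as a single methyl would move the number the other way. The two methyl groups of compound 3 also remain unresolved, since their contribution has not been separated from that of its different core, and a step from the core of compound 2 to a dimethyl analogue would be needed to read it.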